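The source may report more compounds than this note shows. Statements on the series, on what has been measured and on what is new or still open speak of the compounds shown alone.

In an assay on SiHa cells for inhibition of Monocarboxylate transporter 4 (Homo sapiens), read by scintillation counting, with a stated time of 24 h (on this read-out lower numbers stand for stronger inhibition and higher numbers for weaker inhibition), compound 1 `O=C(O)c1cc2ccc(OCc3ccccc3)cc2n(Cc2ccccc2)c1=O` reaches only the limit of the assay, > 30000 nM. In this assay compound 2 `Cc1c(C(=O)O)c(=O)oc2cc(O)ccc12` likewise reaches only the limit, > 30000 nM. Compound 2 therefore stands at the top of what was recorded, a situation summed up by the limit of > 30000 nM in this assay, at which 2 of the 2 values shown sit. Compound 3 `Cc1c(C(=O)O)c(=O)oc2cc(OCc3ccccc3)ccc12` differs from compound 2 by benzyl in place of hydrogen on an oxygen on an aromatic ring. Among the measured compounds shown here, no measured pair differing in a single place is available to size this step. Compound 1 already carries a benzyl ether and stays at its limit. Compound 3 is therefore expected to stay near the limit as well, at about 40000 nM within a range of 8000 nM to 200000 nM. That estimate means an expected step from compound 2 to compound 3 of a step that the limit leaves unreadable from compound 2 to compound 3, nothing beyond the usual scatter.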

Compound 3, half-maximal inhibitory concentration: > 30000 nM
Compound 3: only a limit was reported; the forecaster's own chance of this, stated with the estimate: 70%; the middle value does not contradict the limit.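

Compound 2 and compound 3 both stop at a limit in this assay, and the step between them cannot be read. The compounds shown leave open which change, if any, would bring a value within the assay's measurable range.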